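The compounds below may be only part of what the source reports. "The series", "measured", "known", "first", "only" and "open" are said of these compounds alone.

Three compounds share one core and differ only in the group on the amide-type nitrogen. In an assay on HEK293 cells for agonist activity at Toll-like receptor 2 (Homo sapiens) (on this read-out lower numbers stand for an effect already at smaller amounts and higher numbers for an effect only at larger amounts of compound), compound 1 `CCCCCCCCCCCC(=O)OC[C@H](CSC[C@@H](N)C(=O)N[C@H](C)CO)OC(=O)CCCCCCCCCCC` gives 22200 nM. Compound 2 `CCCCCCCCCCCC(=O)OC[C@H](CSC[C@@H](N)C(=O)NC1(CO)CC1)OC(=O)CCCCCCCCCCC` gives 265 nM, and compound 3 `CCCCCCCCCCCC(=O)OC[C@H](CSC[C@@H](N)C(=O)NC(CC)COC)OC(=O)CCCCCCCCCCC` gives 71.8 nM. Compound 2 therefore stands second highest of the three numbers: the step of an 84-fold lower number from compound 1 to compound 2 (1.92 log units; beyond the scatter) was large, and the step of a 3.7-fold lower number from compound 2 to compound 3 (0.57 log units; beyond the scatter) was modest.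

Compound 4 `CCCCCCCCCCCC(=O)OC[C@H](CSC[C@@H](N)C(=O)N[C@@H](CC)COCC(=O)O)OC(=O)CCCCCCCCCCC` is the next candidate. Its change from compound 2 reads (1-((carboxymethoxy)methyl)propyl in place of 1-(hydroxymethyl)cyclopropyl on an amide-type nitrogen). Going by the values given here, the closest measured step is the one from compound 2 to compound 3, where a propyl carrying a methoxymethyl group replaced the hydroxymethyl-cyclopropyl and lowered the number. Among the compounds with values here, compound 4 carries the same propyl with a carboxymethoxy-methyl group instead; the extra carboxymethyl has no measured counterpart here. A modest lowering, a 2.7-fold lower number from compound 2 to compound 4 (0.42 log units; beyond the scatter), is therefore expected, close to what compound 3 showed. In this assay compound 4 is estimated at 100 nM, with a range from 25 nM to 400 nM.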

Compound 4, half-maximal effective concentration: 6500 nM
Compound 4: middle estimate off by 65-fold (1.81 log units), on the low side; measured number above the stated range.
By their numbers in this assay, from the lowest: compound 3; then compound 2; then compound 4; then compound 1.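

Putting a carboxymethoxy-methyl end in place of the methoxymethyl end on the same propyl group gives a 91-fold higher number from compound 3 to compound 4 (1.96 log units; beyond the scatter), so at this amide-type nitrogen the far end of the side chain can matter a great deal. The direction seen earlier also reverses: compound 3 had a lower number than compound 2, but here the change gives a 25-fold higher number from compound 2 to compound 4 (1.39 log units; beyond the scatter). Even so, compound 4 keeps some advantage over the 1-(hydroxymethyl)ethyl group, with a 3.4-fold lower number from compound 1 to compound 4 (0.53 log units; beyond the scatter), and compound 1 retains the highest number of the four.

Nothing available here explains why the number rose so steeply. The compounds shown leave open whether an amine or a methyl ester at the end of this chain would give a number close to that of compound 3 or one closer to that of compound 4.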